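Chloro in Place of Methyl on Two Ester Cores

A few compounds are considered here, and "the series" means these few. Any claim that something is new, unique, unknown or untested is made for them only; others in the source may bear on it.

Of the compounds shown here, three have been measured in a functional assay on HeLa cells (Homo sapiens) for cytotoxicity, read by MTT assay, with a stated time of 48 h; on this read-out higher numbers stand for weaker inhibition and lower numbers for stronger inhibition. Compound 1 `CCOC(=O)c1c(-c2cc3ccccc3oc2=O)nn(-c2cccc(C)c2)c1C(=O)OCC` gives 245000 nM in this assay. Compound 3 `CCOC(=O)c1c(-c2cc3ccccc3oc2=O)nn(-c2cccc(Cl)c2)c1C(=O)OCC` differs from compound 1 by chloro in place of methyl on an aromatic carbon, and this change gave an 11-fold lower number from compound 1 to compound 3 (1.05 log units; beyond the scatter). In this assay compound 3 gives 22000 nM. Compound 2 `COC(=O)c1c(-c2cc3ccccc3oc2=O)nn(-c2cccc(C)c2)c1C(=O)OC` gives 45000 nM in this assay; the difference between the core of compound 2 and the core of compound 1 is not broken down here. Compound 4 `COC(=O)c1c(-c2cc3ccccc3oc2=O)nn(-c2cccc(Cl)c2)c1C(=O)OC` is not yet measured and differs from compound 2 by chloro in place of methyl on an aromatic carbon, the same change as that from compound 1 to compound 3, at the same place. Resting on the step of an 11-fold lower number from compound 1 to compound 3 (1.05 log units; beyond the scatter), a step of similar size is expected, a 9.0-fold lower number from compound 2 to compound 4 (0.95 log units; beyond the scatter). Compound 4 is therefore estimated at 5000 nM in this assay, between 1500 nM and 20000 nM.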

Compound 4, half-maximal inhibitory concentration: 76000 nM
Compound 4: middle estimate off by 15-fold (1.18 log units), on the low side; measured number above the stated range.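

In this assay, 3-methylphenyl to 3-chlorophenyl gave a 1.7-fold higher number from compound 2 to compound 4 (0.23 log units; within the scatter), so the large step seen on the core of compound 1 did not carry over to the core of compound 2: the same change on two cores in this assay, an 11-fold lower number (1.05 log units; beyond the scatter) from compound 1 to compound 3 and a 1.7-fold higher number (0.23 log units; within the scatter) from compound 2 to compound 4, 19-fold (1.27 log units) apart, beyond the scatter of two such steps. Across these two matched pairs, the effect of this change therefore depends on the core, and a step read on one core cannot be assumed to hold on the other. The four compounds do not show why the cores differ or how the change would behave on any further core.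

Going by these compounds, it remains open whether other groups at the same place, such as fluoro, methoxy or an amine, would also depend on the core. The same question stands for cores carrying a carboxylic acid or an amide in place of the esters.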